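The compounds below may be only part of what the source reports. "The series", "measured", "known", "first", "only" and "open" are said of these compounds alone.

Measured in a functional assay on MCF7 cells (Homo sapiens) for antiproliferative activity, read by MTT assay, with a stated time of 48 h; a lower number here means a stronger inhibitor, a higher number a weaker inhibitor:
compound 1 `COc1ccc(-c2nc(C)c(C(=O)CSc3nc(N)c(C#N)c(-c4ccc(Cl)cc4)n3)s2)cc1` gives 11300 nM
compound 2 `COc1ccc(-c2nc(C)c(C(=O)CSc3nc(N)c(C#N)c(-c4ccccc4)n3)s2)cc1` gives 72100 nM

Compound 1 holds the lower of the two numbers. Next is compound 3 `Cc1nc(-c2ccc(Cl)cc2)sc1C(=O)CSc1nc(N)c(C#N)c(-c2ccc(Cl)cc2)n1`, which carries chloro in place of methoxy on an aromatic carbon, 4-methoxyphenyl to 4-chlorophenyl: chloro in place of methoxy on an aromatic carbon. Within the data shown here, the only measured step, a 6.4-fold higher number from compound 1 to compound 2 (0.80 log units; beyond the scatter), puts hydrogen in place of chloro elsewhere in the molecule, so it bears only indirectly. Among the measured compounds shown here, no measured step touches the methoxy position. A small move toward a lower number in this assay is expected, probably within the scatter: a 1.3-fold lower number from compound 1 to compound 3 (0.10 log units; within the scatter). For compound 3 the estimated value is 9000 nM, with an expected range of 3000 nM to 27000 nM.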

Compound 3, half-maximal inhibitory concentration: 12500 nM
Estimate against measurement, compound 3: 1.4-fold (0.14 log units) below, and the stated range covers the measured number.
By their numbers in this assay, from the lowest: compounds 1 and 3 (each within the scatter of the next); then compound 2.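

In this assay, 4-chlorophenyl in place of 4-methoxyphenyl gives a 1.1-fold higher number from compound 1 to compound 3 (0.04 log units; within the scatter), so this position accepts the exchange without a readable difference. Hydrogen in place of chloro elsewhere in the molecule gave a 6.4-fold higher number from compound 1 to compound 2 (0.80 log units; beyond the scatter), so the earlier step does not carry over to this position. No supporting data bear on why methoxy and chloro read alike here.

Open, on these data alone, is how an amine or a carboxylic acid would read at this position. Also open, as far as these compounds go, is whether the match between methoxy and chloro holds when the other chloro is replaced by hydrogen.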